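Plasma stability along the aryloxy-benzothiazole series: guanidine to amine

The source may hold more compounds than are shown below. What is called first, only, known or untested is meant among the compounds shown, and "the series" means these compounds.

Compound 1 `CN(Cc1ccc(OCCCNC(=N)N)cc1)c1nc2ccc(Oc3cccc(C(F)(F)F)c3)cc2s1` has been measured in an ADME assay on a cell-free system (plasma, Rattus norvegicus) for metabolic stability, read by HPLC, with a stated time of 24 h, tested at 120 uM (a higher number here means that more of the compound is left, a lower number that less of the compound is left), where compound 1 gives 95%. Of the two numbers at hand, compound 1 sits alongside compound 2 `N=C(N)NCCCOc1ccc(CNc2nc3ccc(Oc4ccc(C(F)(F)F)cc4)cc3s2)cc1`, which in this assay gives 91%, the gap between the two lying within the scatter. Compound 3 `CN(Cc1ccc(OCCCN)cc1)c1nc2ccc(Oc3cccc(C(F)(F)F)c3)cc2s1` is not yet measured. The change from compound 1 to compound 3 is a hydrogen atom in place of a group of 3 heavy atoms (1 carbon, 2 nitrogen; no ring), on an amine nitrogen. Going by the values given here, no step between measured compounds is at hand for this kind of change; the step from compound 1 to compound 3 is expected to be small, none beyond the scatter, so that compound 3 is expected to stay at 92% (range 80% to 100%), a step of a number 3 percentage points lower from compound 1 to compound 3 (within the scatter).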

Compound 3, percent of the compound remaining: 100%
For compound 3 the middle estimate is 8 percentage points below the measured one; the measured number falls inside the stated range.
By their numbers in this assay, from the lowest: compounds 2, 1 and 3 (each within the scatter of the next).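

Going by these compounds alone, this is the first reading at this position: with a hydrogen atom in place of the group of 3 heavy atoms on the amine nitrogen, this assay gives a number 5 percentage points higher from compound 1 to compound 3 (within the scatter) and so shows no change beyond the scatter. Stability in this assay therefore does not depend on that group in the core of compound 1. No measurement at hand bears on why the reading holds.

Going by these compounds, whether a carboxylic acid or an acetamide on this chain would read alike remains open. So does the effect of a longer chain.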